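Piperidin-2-yl in place of 1-amino-1-methylethyl

The source may hold more compounds than are shown below. What is called first, only, known or untested is meant among the compounds shown, and "the series" means these compounds.

Three compounds share one core and differ in the group on a single carbonyl carbon. All three have been measured in a physicochemical assay for solubility, read by chemiluminescence, measured as kinetic solubility; a lower number here means a less soluble compound, a higher number a more soluble compound. For the measured compounds named here, compound 1 `COc1cccc2c1c(NS(=O)(=O)c1ccc(Cl)s1)nn2Cc1cccc(CNC(=O)C2CCO2)c1` gives 124 ug/mL, the only exact number among them. Compound 2 `COc1cccc2c1c(NS(=O)(=O)c1ccc(Cl)s1)nn2Cc1cccc(CNC(=O)C2CCCO2)c1` reads >= 153 ug/mL, which is a limit of the assay and not a number. Compound 3 `COc1cccc2c1c(NS(=O)(=O)c1ccc(Cl)s1)nn2Cc1cccc(CNC(=O)C(C)(C)N)c1` reads >= 180 ug/mL, which is also a limit. Compound 3 therefore has no exact place on the scale.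

Compound 4 `COc1cccc2c1c(NS(=O)(=O)c1ccc(Cl)s1)nn2Cc1cccc(CNC(=O)[C@@H]2CCCCN2)c1` carries piperidin-2-yl in place of 1-amino-1-methylethyl on a carbonyl carbon. Going by the values given here, no measured compound carries piperidin-2-yl, so the guidance is indirect. Exchanging oxetan-2-yl for 1-amino-1-methylethyl gives an at least 1.4-fold higher number from compound 1 to compound 3 (0.16 log units; that floor lies within the scatter), and exchanging it for oxolan-2-yl gives an at least 1.2-fold higher number from compound 1 to compound 2 (0.09 log units; that floor lies within the scatter). Between the remaining pair there is a step that the two limits leave unreadable from compound 2 to compound 3, so these steps give no ground for expecting a change beyond the scatter in this assay.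

The expected step is an at least 1.0-fold lower number from compound 3 to compound 4 (0.03 log units; that floor lies within the scatter). For compound 4 the estimate is 165 ug/mL, with an expected range from 90 ug/mL to 230 ug/mL. The result may also arrive as a limit rather than a number.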

Compound 4, solubility: >= 220 ug/mL
Compound 4 was reported as a limit (the forecaster's own chance of this, stated with the estimate: 55%); middle value at least 1.3-fold (0.12 log units) away from the limit.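

In this assay compound 4 joins the compounds that read as a limit and not as a number, so a piperidin-2-yl ring on this carbonyl carbon also gives no exact place on the scale: the limit of >= 220 ug/mL in this assay, at which 1 of the 4 values shown sits.

For the compounds shown here, the one step that can be read is an at least 1.7-fold higher number from compound 1 to compound 4 (0.24 log units; that floor lies within the scatter), and it shows that a six-membered non-aromatic ring at this position does not bring the reading down to an exact value, though its floor alone does not establish a change beyond the scatter. The steps from compound 2 and from compound 3 to compound 4 cannot be read, as both ends of each are limits, so the ring and the open chain of 1-amino-1-methylethyl cannot be ranked against each other.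

From the compounds shown here alone, the true values of compound 2, compound 3 and compound 4 stay unknown, and with them the real size of every step that reaches them. Also open, going by these compounds, is what the ring nitrogen contributes, which a cyclohexyl group, all carbon in the ring, or the opposite stereoisomer of piperidin-2-yl could help to separate.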